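Working notes on the series: from compound 1 to compound 4

The source may report more compounds than this note shows. Statements on the series, on what has been measured and on what is new or still open speak of the compounds shown alone.

Measured so far in an assay on HEK-293T cells for antagonist activity at vitamin D3 receptor (Homo sapiens), read by a luciferase reporter, with a stated time of 24 h; on this read-out lower numbers stand for stronger inhibition and higher numbers for weaker inhibition:
compound 1 `CC(C)c1onc(-c2c(Cl)cccc2Cl)c1COc1ccc(-c2nc3ccc(C(=O)O)cc3n2CC(C)(C)C)cc1`: 861 nM
compound 2 `CC(C)c1onc(-c2c(Cl)cccc2Cl)c1COc1ccc(-c2nc3ccc(C(=O)O)cc3n2CC2CCCCC2)cc1`: 346 nM
compound 3 `CC(C)c1onc(-c2c(Cl)cccc2Cl)c1COc1ccc(-c2nc3ccc(C(=O)O)cc3n2C)cc1Cl`: 2450 nM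

Compound 1 stands second highest of the three numbers. Within the data shown here, its nearest neighbour is compound 2, whose number is lower, and the furthest is compound 3, whose number is higher; no step is defined for the pair of compound 1 and compound 3, since they differ in more than one place, so only the two values themselves are noted.

Compound 4 `CC(=O)C1CCC(Cn2c(-c3ccc(OCc4c(-c5c(Cl)cccc5Cl)noc4C(C)C)cc3)nc3ccc(C(=O)O)cc32)CC1` is not yet measured. Against compound 1 the change is 4-acetylcyclohexyl in place of tert-butyl on a saturated chain carbon bound to an aromatic nitrogen.

Among the measured compounds shown here, the one measured step that bears on this is a 2.5-fold lower number from compound 1 to compound 2 (0.40 log units; beyond the scatter), the replacement of the same tert-butyl by a plain cyclohexyl on the same saturated chain carbon bound to an aromatic nitrogen. Compound 4 carries a cyclohexyl as well, with an acetyl on its far position that adds one hydrogen-bond acceptor. For the measured compounds named here, the step to compound 2 gives the only guide, so a comparable lowering is expected for compound 4, with wider uncertainty because the acetyl has no precedent among the measured compounds. The expected step is a 2.2-fold lower number from compound 1 to compound 4 (0.33 log units; beyond the scatter). For compound 4 the estimate in this assay is 400 nM, within a range of 150 nM to 1000 nM.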

Compound 4, half-maximal inhibitory concentration: > 10000 nM
Compound 4: a limit, no number (the forecaster's own chance of this, stated with the estimate: 5%); middle value at least 25-fold (1.39 log units) away from the limit.
By their numbers in this assay, from the lowest: compound 2; then compound 1; then compound 3. At a limit, above all of these: compound 4.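

In this assay, compound 4 gives > 10000 nM, which is a limit of the assay and not a number: the limit of > 10000 nM in this assay, at which 1 of the 4 values shown sits.

The saturated chain carbon bound to an aromatic nitrogen accepted a plain cyclohexyl in place of tert-butyl, but the series now shows that a larger group there does not always lower the number, since 4-acetylcyclohexyl gives an at least 11-fold higher number from compound 1 to compound 4 (1.06 log units; beyond the scatter). The closer comparison is an at least 28-fold higher number from compound 2 to compound 4 (1.46 log units; beyond the scatter), acetyl in place of hydrogen on a saturated ring carbon, which places the whole change on the acetyl and not on the cyclohexyl ring that compound 2 also carries.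

The compounds shown leave open whether a methyl, a hydroxyl or an amine on that saturated ring carbon would read like the hydrogen of compound 2 or like the acetyl of compound 4. The limit for compound 4 also leaves open how large both steps really are, and the data give no cause for them.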